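3-(4-Chlorophenoxy)propyl to (4-fluorophenyl)carbamoyl on an aromatic oxygen

A few compounds are considered here, and "the series" means these few. Any claim that something is new, unique, unknown or untested is made for them only; others in the source may bear on it.

Measured compounds:
compound 1 `CC(C)=CCC/C(C)=C/CC1Cc2c(O)cc(=O)n(CCCO)c2CC1(C)C`: 0%
compound 2 `CC(C)=CCC/C(C)=C/CC1Cc2c(OCCCOc3ccc(Cl)cc3)cc(=O)n(CCCO)c2CC1(C)C`: 0%

In a functional assay on PANC-1 cells (Homo sapiens) for inhibition, read by MTT assay, with a stated time of 24 h, tested at 10 uM (on this read-out lower numbers stand for less inhibition and higher numbers for more inhibition at the one concentration tested (going by the name of the read-out)), compound 1 gives 0%. In the same assay compound 2 gives 0%. Among the compounds with values here, the one measured step, no change at the digits printed from compound 1 to compound 2 (within the scatter), attaches a 3-(4-chlorophenoxy)propyl group to the oxygen on the aromatic ring. Compound 2 thus stands level with compound 1; neither shows inhibition beyond the scatter.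

Compound 3 `CC(C)=CCC/C(C)=C/CC1Cc2c(OC(=O)Nc3ccc(F)cc3)cc(=O)n(CCCO)c2CC1(C)C` differs from compound 2 in one place: (4-fluorophenyl)carbamoyl in place of 3-(4-chlorophenoxy)propyl on an oxygen on an aromatic ring. Within the data shown here, the only step that bears on this change is the one from compound 1 to compound 2, where adding a group at this oxygen gave no change. Among the measured compounds shown here, no measured step involves a (4-fluorophenyl)carbamoyl group, so nothing in the numbers points to a shift in either direction. For compound 3 the expected step is no change at the digits printed from compound 2 to compound 3 (within the scatter), that is, none beyond the scatter. Compound 3 is therefore estimated at 0%, with a range from 0% to 15%.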

Compound 3, a percentage reported as inhibition, at one concentration (the size of the read-out at that concentration, not a potency): 6.2%
The estimate for compound 3 lay 6.2 percentage points below the measured number; measured number inside the range.
By their numbers in this assay, from the lowest: compounds 1, 2 and 3 (each within the scatter of the next).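

With (4-fluorophenyl)carbamoyl on the oxygen on the aromatic ring, the replacement of 3-(4-chlorophenoxy)propyl gives a number 6.2 percentage points higher from compound 2 to compound 3 (within the scatter), and the replacement of hydrogen gives a number 6.2 percentage points higher from compound 1 to compound 3 (within the scatter). A second, different group at this oxygen, one that brings a hydrogen-bond donor and a double bond outside the aromatic rings, therefore still yields no step beyond the scatter in this assay, so the insensitivity seen with the first group is not confined to that ether-linked chain. No supporting measurement is available to explain this result.

From the compounds shown here alone, it remains open whether a basic amine such as a piperidine, a carboxylic acid or a longer chain at this oxygen would produce a step beyond the scatter. The compounds shown also leave open what changes elsewhere on the shared core would do, such as replacing the 3-hydroxypropyl chain.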